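Swapping a Trifluoromethyl for a Nitro Group

The source may report more compounds than this note shows. Statements on the series, on what has been measured and on what is new or still open speak of the compounds shown alone.

For the measured compounds named here, compound 1 `Cc1cc2c(C(C)C)ccc(C)c2cc1OC(=O)c1ccc(C(F)(F)F)cc1` gives 55.6% in a functional assay on HCT-15 cells (Homo sapiens) for antiproliferative activity, read by sulforhodamine B assay, with a stated time of 48 h, tested at 50 uM (a lower number here means less inhibition, a higher number more inhibition at the concentration tested (going by the name of the read-out)), the highest of the two numbers measured so far. Compound 2 `CC1=CC[C@H](C(C)C)c2cc(C)c(OC(=O)c3ccc(C(F)(F)F)cc3)cc21` gives 6.4% in this assay, a number far lower than that of compound 1 and beyond the usual scatter. Compound 3 `Cc1cc2c(C(C)C)ccc(C)c2cc1OC(=O)c1ccc([N+](=O)[O-])cc1` has not yet been measured; it keeps the core of compound 1 and differs only in nitro in place of trifluoromethyl on an aromatic carbon. Going by the values given here, no measured pair shows this exchange, so the change is expected to be modest, likely within the scatter. The expected step is a number 5.6 percentage points lower from compound 1 to compound 3 (within the scatter). Compound 3 is therefore estimated at 50%, within a range from 25% to 75%.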

Compound 3, a percentage reported as inhibition, at one concentration (the size of the read-out at that concentration, not a potency): 97.6%
Beside the measured number, compound 3's estimate is 47.6 percentage points below it, outside the stated range (above it).
By their numbers in this assay, from the lowest: compound 2; then compound 1; then compound 3.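

Nitro in place of trifluoromethyl, on an aromatic carbon para to a large group, gives a number 42 percentage points higher from compound 1 to compound 3 (beyond the scatter) in this assay. The earlier compounds shown here kept trifluoromethyl at this place, so they could not show that the group there matters; this single exchange, with the rest of the molecule unchanged, moves the read-out far beyond the scatter.

Going by these compounds, whether an amine or a carboxylic acid at this place would raise or lower the read-out stays open, as does the effect of the same exchange on the core of compound 2. No measurement shown here explains the size of this step.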